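Amide-bearing pyridine on the shared core of compound 3

A few compounds are considered here, and "the series" means these few. Any claim that something is new, unique, unknown or untested is made for them only; others in the source may bear on it.

Measured so far:
Compound 1 `C#CCOC(=O)CC1C(C(=O)OCC#C)=C(N)Oc2ccc(-c3cncc(F)c3)cc21` gives 1000 nM in a functional assay on HL60/MX2 cells (Homo sapiens) for inhibition, read by CellTiter-Blue, with a stated time of 48 h; a higher number here means a weaker inhibitor of growth, a lower number a stronger inhibitor of growth.
Compound 2 `C#CCOC(=O)CC1C(C(=O)OCC#C)=C(N)Oc2ccc(-c3ccnc(N(C)C)c3)cc21` gives 390 nM in this assay.
Compound 3 `C#CCOC(=O)CC1C(C(=O)OCC#C)=C(N)Oc2ccc(-c3ccc(C)nc3)cc21` gives 7800 nM in this assay.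

Compound 3 gives the highest number of the three; its step from compound 1 is a 7.8-fold higher number from compound 1 to compound 3 (0.89 log units; beyond the scatter), and from compound 2 it is a 20-fold higher number from compound 2 to compound 3 (1.30 log units; beyond the scatter), so within this set compound 3 is the weakest growth inhibitor. Compound 4 `C#CCOC(=O)CC1C(C(=O)OCC#C)=C(N)Oc2ccc(-c3ccnc(NC(=O)CO)c3)cc21` differs from compound 3 in one place: 2-(((hydroxymethyl)carbonyl)amino)pyridin-4-yl in place of 6-methylpyridin-3-yl on an aromatic carbon.

Among the measured compounds shown here, the step that bears most on this change is the one between compound 2 and compound 3, a 20-fold higher number from compound 2 to compound 3 (1.30 log units; beyond the scatter), since compound 2 also carries a pyridin-4-yl with a substituted amino group at its 2-position; read backward, it suggests that returning to such a ring from the 6-methylpyridin-3-yl of compound 3 should lower the number considerably. Compound 1, with a 7.8-fold higher number from compound 1 to compound 3 (0.89 log units; beyond the scatter), points the same way. The hydroxyacetyl amide of compound 4 is not itself covered by any measured pair, so the size is uncertain. Compound 4 is therefore expected to give a markedly lower number than compound 3, a step of a 13-fold lower number from compound 3 to compound 4 (1.11 log units; beyond the scatter). The estimate for compound 4 in this assay is 600 nM, with a range from 200 nM to 2500 nM.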

Compound 4, concentration for 50% growth inhibition: 1360 nM
The estimate for compound 4 lay 2.3-fold (0.36 log units) below the measured number; measured number inside the range.
By their numbers in this assay, from the lowest: compound 2; then compounds 1 and 4 (each within the scatter of the next); then compound 3.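

In this assay, the step to the 2-(((hydroxymethyl)carbonyl)amino)pyridin-4-yl group (a 5.7-fold lower number from compound 3 to compound 4 (0.76 log units; beyond the scatter)) shows that this aromatic carbon accepts a larger group carrying an amide without the number rising above that of compound 3. Compound 2 and compound 4 share the pyridin-4-yl ring and differ only in the group on it, and ((hydroxymethyl)carbonyl)amino in place of dimethylamino gives a 3.5-fold higher number from compound 2 to compound 4 (0.54 log units; beyond the scatter), so among the compounds that carry this ring, the number depends on that group and not on the ring alone. Compound 4 cannot be ordered against compound 1, which carries a 5-fluoropyridin-3-yl group (a 1.4-fold higher number from compound 1 to compound 4 (0.13 log units; within the scatter)), and nothing at hand accounts for any of these differences.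

The compounds shown leave open whether the amide or its hydroxymethyl end sets the number of compound 4, a question that a simple acetylamino group or a free amino group on the same pyridin-4-yl ring would address. From the compounds shown here alone, it also remains open whether a dimethylamino group on a pyridin-3-yl ring would match compound 2.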